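Swapping the sulfonyl aryl group on a weak pancreatic-cancer inhibitor

A few compounds are considered here, and "the series" means these few. Any claim that something is new, unique, unknown or untested is made for them only; others in the source may bear on it.

Compound 1 `COc1ccc(S(=O)(=O)NCCCCCCNCc2ccc(Br)cc2)cc1` is the weakest of the three measured compounds: in a functional assay on MIA PaCa-2 cells (Homo sapiens) for inhibition, read by MTT assay, with a stated time of 72 h (on this read-out lower numbers stand for stronger inhibition of growth and higher numbers for weaker inhibition of growth), compound 1 gives 13000 nM, whereas compound 2 `O=S(=O)(NCCCCCCNCc1ccc(Br)cc1)c1ccc(C(F)(F)F)cc1` gives 3830 nM and compound 3 `CC(C)(C)c1ccc(S(=O)(=O)NCCCCCCNCc2ccc(Br)cc2)cc1` gives 2970 nM. Compound 4 `O=[N+]([O-])c1ccccc1S(=O)(=O)NCCCCCCNCc1ccc(Br)cc1` differs from compound 1 by 2-nitrophenyl in place of 4-methoxyphenyl on a sulfonyl sulfur. Within the data shown here, the closest precedents are the modest improvements a 3.4-fold lower number from compound 1 to compound 2 (0.53 log units; beyond the scatter) and a 4.4-fold lower number from compound 1 to compound 3 (0.64 log units; beyond the scatter), both from replacing the methoxy group; no step with a nitro group exists, so these bear only loosely. A modest gain is nevertheless expected, with the estimate for compound 4 in this assay at 6000 nM (range 2500 nM to 15000 nM), corresponding to an expected step of a 2.2-fold lower number from compound 1 to compound 4 (0.34 log units; beyond the scatter).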

Compound 4, concentration for 50% growth inhibition: 11700 nM
Beside the measured number, compound 4's estimate is 2.0-fold (0.29 log units) below it, and the stated range covers the measured number.
By their numbers in this assay, from the lowest: compounds 3 and 2 (each within the scatter of the next); then compounds 4 and 1 (each within the scatter of the next).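

In this assay, 2-nitrophenyl in place of 4-methoxyphenyl on a sulfonyl sulfur gives a 1.1-fold lower number from compound 1 to compound 4 (0.05 log units; within the scatter) and so no real change. Removing the methoxy group is therefore not enough on its own to gain activity, although the earlier replacements gave a 3.4-fold lower number from compound 1 to compound 2 (0.53 log units; beyond the scatter) and a 4.4-fold lower number from compound 1 to compound 3 (0.64 log units; beyond the scatter) as clear, modest gains. No measurement available here explains this difference between the replacements.

On these data alone, it remains open how an amine or a carboxylic acid on this aromatic ring would behave, and whether any such group could improve on the trifluoromethyl and tert-butyl compounds.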